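A few compounds are considered here, and "the series" means these few. Any claim that something is new, unique, unknown or untested is made for them only; others in the source may bear on it.

Measured compounds:
compound 1 `CCCC[C@H](C)[C@H](OC(N)=O)[C@@H](C)[C@H](O)[C@@H](C)C/C(C)=C\[C@H](C)[C@@H](O)[C@@H](C)CCCC[C@@H]1OC(=O)[C@H](C)[C@@H](O)[C@H]1C` — 309 nM
compound 2 `C=C/C=C\[C@H](C)[C@H](OC(N)=O)[C@@H](C)[C@H](O)[C@@H](C)C/C(C)=C\[C@H](C)[C@@H](O)[C@@H](C)/C=C\[C@@H](O)C[C@@H]1OC(=O)C(C)=C[C@H]1C` — 33.6 nM
compound 3 `CCCC[C@H](C)[C@H](OC(N)=O)[C@@H](C)[C@H](O)[C@@H](C)C/C(C)=C\[C@H](C)[C@@H](O)[C@@H](C)/C=C\[C@@H](O)C[C@@H]1OC(=O)[C@H](C)[C@@H](O)[C@H]1C` — 10 nM

In a functional assay on P388 cells (Mus musculus) for cytotoxicity (a lower number here means a stronger inhibitor, a higher number a weaker inhibitor), compound 1 stands highest of the three numbers shown; the nearest is compound 2 and the furthest compound 3, both gaps beyond the scatter. Compound 4 `CCCC[C@H](C)[C@H](OC(N)=O)[C@@H](C)[C@H](O)[C@@H](C)C/C(C)=C\[C@H](C)[C@@H](O)[C@@H](C)CC[C@@H](O)C[C@@H]1OC(=O)[C@H](C)[C@@H](O)[C@H]1C` is not yet measured. It differs from compound 1 by hydroxy in place of hydrogen on a saturated chain carbon bound to two saturated chain carbons. Going by the values given here, no measured pair shows this step alone, so its size is unknown. Given that compound 3 gives 10 nM while compound 1 gives 309 nM, a downward step is expected, of moderate size and beyond the scatter. Compound 4 is estimated at 45 nM, with a range of 12 nM to 160 nM, which means an expected step of a 6.9-fold lower number from compound 1 to compound 4 (0.84 log units; beyond the scatter).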

Compound 4, half-maximal inhibitory concentration: 33.8 nM
Estimate against measurement, compound 4: 1.3-fold (0.12 log units) above; the measured number falls inside the stated range.
By their numbers in this assay, from the lowest: compound 3; then compounds 2 and 4 (each within the scatter of the next); then compound 1.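

In this assay, hydroxy in place of hydrogen on a saturated chain carbon bound to two saturated chain carbons gives a 9.1-fold lower number from compound 1 to compound 4 (0.96 log units; beyond the scatter), the only single-change step shown in the series. Going by these compounds alone, this carbon therefore responds to substitution, which the earlier compounds, differing in more than one place, could not establish. No measurement bearing on the cause of this step is available.

As far as these compounds go, it remains open whether a methoxy group, an amine or a ketone carbonyl on this carbon would give a step of similar size. The opposite configuration of the hydroxy-bearing carbon also remains untested among the compounds shown.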